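The compounds below may be only part of what the source reports. "The series", "measured", "known", "first", "only" and "open" are said of these compounds alone.

Working notes on the solubility series built on the shared core seen in compound 1 `CC(C)C(NC(=O)c1ccc(C#Cc2ccccc2)cc1)C(=O)NO`. In a physicochemical assay for solubility (on this read-out lower numbers stand for lower solubility and higher numbers for higher solubility), compound 1 gives 7000 nM. Among the measured compounds shown here, compound 2 `O=C(NC1(C(=O)NO)CCC1)c1ccc(C#Cc2ccccc2)cc1` gives 5000 nM; the change a 1.4-fold lower number from compound 1 to compound 2 (0.15 log units; within the scatter) is the only one-place step among the measured compounds. Compound 3 `NC(=O)C[C@H](NC(=O)c1ccc(C#Cc2ccccc2)cc1)C(=O)NO` gives 61000 nM and stands highest of the three numbers, well beyond the scatter from both compound 1 and compound 2.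

Compound 4 `COCCNC(=O)C[C@H](NC(=O)c1ccc(C#Cc2ccccc2)cc1)C(=O)NO` differs from compound 3 by 2-methoxyethyl in place of hydrogen on an amide-type nitrogen. For the measured compounds named here, no measured step touches an amide-type nitrogen in this way; the one recorded step, from compound 1 to compound 2, concerns a different part of the molecule and stayed within the scatter, so it offers no direction. With nothing to rest on beyond the position of compound 3, the expectation for compound 4 in this assay is a step of a 1.5-fold lower number from compound 3 to compound 4 (0.18 log units; within the scatter), not clearly beyond the scatter. Compound 4 is therefore estimated at 40000 nM, with a range from 15000 nM to 100000 nM.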

Compound 4, solubility: 78000 nM
For compound 4 the middle estimate is 2.0-fold (0.29 log units) below the measured one; measured number inside the range.
By their numbers in this assay, from the lowest: compounds 2 and 1 (each within the scatter of the next); then compounds 3 and 4 (each within the scatter of the next).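

Among the compounds shown here, compound 4 gives the first reading of a substituent on this amide-type nitrogen: with 2-methoxyethyl in place of hydrogen, this assay shows a 1.3-fold higher number from compound 3 to compound 4 (0.11 log units; within the scatter). At this position, the change from carbamoyl to (2-methoxyethyl)carbamoyl therefore leaves the read-out indistinguishable from that of compound 3, so this nitrogen can carry the 2-methoxyethyl chain without a step beyond the scatter. No measurement on hand explains this result.

As far as these compounds go, whether the same holds for other groups on this nitrogen, such as a longer chain, a terminal amine or a carboxylic acid, remains open. A single step also cannot show whether 2-methoxyethyl would read the same way on the amide-type nitrogen of another member of the series.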